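This account rests on a few compounds, and the source may have more. Where it says the series, first, only, none or still open, it means among the compounds named here.

In a functional assay (spleen, spleen) for activation, with Mus musculus as the target (a higher number here means that more compound is needed for the effect, a lower number that less compound is needed), compound 1 `CCCSc1nc(N)c2nc(O)n(Cc3ccccc3)c2n1` gives 0.01 uM, and compound 2 `CCCCCOc1nc(N)c2nc(O)n(Cc3ccccc3)c2n1` gives 0.01 uM. Going by the values given here, the only measured step, no change at the digits printed from compound 1 to compound 2 (within the scatter), shows that exchanging one chain for another left the minimum effective concentration unchanged, so compound 2 stands level with compound 1. Compound 3 `Nc1ncnc2c1nc(O)n2Cc1ccccc1` differs from compound 2 by hydrogen in place of pentyloxy on an aromatic carbon. Among the compounds with values here, no measured step covers removing the chain altogether; the step from compound 1 to compound 2 speaks only to its exchange. Some loss is therefore expected, and the estimated step of a 100-fold higher number from compound 2 to compound 3 (2.00 log units; beyond the scatter) places compound 3 at 1 uM, within a range from 0.1 uM to 10 uM.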

Compound 3, minimum effective concentration: 10 uM
Compound 3: the middle estimate sits 10-fold (1.00 log units) below what was measured; the range from low to high includes it.
By their numbers in this assay, from the lowest: compounds 1 and 2 (each within the scatter of the next); then compound 3.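

In this assay, the substituent on this aromatic carbon, between two ring nitrogen atoms, proves decisive: hydrogen in place of pentyloxy gives a large loss (a 1000-fold higher number from compound 2 to compound 3 (3.00 log units; beyond the scatter)), and hydrogen in place of propylsulfanyl gives the same large loss (a 1000-fold higher number from compound 1 to compound 3 (3.00 log units; beyond the scatter)). The earlier exchange of one chain for the other showed only that these two chains are interchangeable here, whereas these steps show that losing the chain altogether is costly. Nothing available explains this loss. As far as these compounds go, whether an amine such as butylamino would match compound 1 and compound 2 remains open. So does how short a chain, such as methoxy, could be and still keep their level.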